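The source may report more compounds than this note shows. Statements on the series, on what has been measured and on what is new or still open speak of the compounds shown alone.

Of the compounds shown here, three that share one core have been tested in a functional assay on MCF7 cells (Homo sapiens) for inhibition, read by MTT assay, with a stated time of 48 h, tested at 10 uM; a higher number here means more inhibition of growth at the concentration tested, a lower number less inhibition of growth. Compound 1 `O=C(/C=C/c1ccc(OCc2cn(Cc3ccccc3)nn2)cc1)c1ccc(Br)cc1` gives 34% in this assay. Compound 2 `O=C(/C=C/c1ccc(OCc2cn(Cc3ccccc3Br)nn2)cc1)c1ccc(Br)cc1` gives 44%, and compound 3 `O=C(/C=C/c1ccc(OCc2cn(Cc3ccc(Br)cc3)nn2)cc1)c1ccc(Br)cc1` gives 23%. Compound 3 therefore stands lowest of the three: the step of a number 11 percentage points lower from compound 1 to compound 3 (beyond the scatter) is beyond the scatter, as is the step of a number 21 percentage points lower from compound 2 to compound 3 (beyond the scatter), while the step of a number 10 percentage points higher from compound 1 to compound 2 (within the scatter) lies within it.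

Compound 4 `O=C(/C=C/c1ccc(OCc2cn(Cc3ccccc3F)nn2)cc1)c1ccc(Br)cc1` has not yet been measured. It differs from compound 3 in one place: 2-fluorophenyl in place of 4-bromophenyl on a saturated chain carbon bound to an aromatic nitrogen. Going by the values given here, two measured steps bear on this change. Among the compounds with values here, the step of a number 21 percentage points lower from compound 2 to compound 3 (beyond the scatter) exchanged a 2-bromophenyl for a 4-bromophenyl at this same place, a modest drop; the change to compound 4 goes the opposite way, from the 4-bromophenyl back toward a 2-substituted ring, though with fluorine in place of bromine, for which no measured step exists. The step of a number 11 percentage points lower from compound 1 to compound 3 (beyond the scatter) shows that the 4-bromophenyl itself brought a modest drop relative to the plain phenyl. Removing it is thus expected to raise the number. For compound 4 a rise of about a number 12 percentage points higher from compound 3 to compound 4 (beyond the scatter) in this assay is therefore expected. Compound 4 is estimated at roughly 35%, within a range from 20% to 50%.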

Compound 4, percent growth inhibition at one concentration: 38%
Beside the measured number, compound 4's estimate is 3 percentage points below it, within the range that was stated.
By their numbers in this assay, from the lowest: compound 3; then compounds 1, 4 and 2 (each within the scatter of the next).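

On the saturated chain carbon bound to an aromatic nitrogen, 2-fluorophenyl in place of 4-bromophenyl gives a number 15 percentage points higher from compound 3 to compound 4 (beyond the scatter) in this assay, which shows that the low number of compound 3 is not shared by every halogen-bearing ring at this position. The other two new steps, a number 6 percentage points lower from compound 2 to compound 4 (within the scatter) and a number 4 percentage points higher from compound 1 to compound 4 (within the scatter), both stay within the scatter, so compounds 1, 2 and 4 cannot be told apart in this assay, and only compound 3 stands apart from all three. Nothing measured here accounts for this pattern.

The step from 4-bromophenyl to 2-fluorophenyl changes both the halogen and where it sits on the ring, so these compounds cannot say which of the two matters, and a 4-fluorophenyl group would be the direct comparison. Also open, from the compounds shown here alone, is how this position responds to groups of another kind, such as an amine or a carboxylic acid on the ring, or to a longer chain between the ring and the aromatic nitrogen.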